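The compounds below may be only part of what the source reports. "The series", "measured", "known", "first", "only" and "open" are said of these compounds alone.

Within the data shown here, compound 3 `COc1ccc(Cn2cc(CN(Cc3cn(S(=O)(=O)c4ccc(C)cc4)c4ccccc34)S(=O)(=O)c3ccc(C)cc3)nn2)cc1` stands highest of the three compounds measured so far in a functional assay on 3T3-L1 cells (Mus musculus) for inhibition, with a stated time of 20 min, tested at 20 uM (on this read-out higher numbers stand for more inhibition at the one concentration tested (going by the name of the read-out) and lower numbers for less inhibition), where compound 3 gives 1%. Its nearest neighbour is compound 2 `Cc1ccc(S(=O)(=O)N(Cc2cccc(F)c2F)Cc2cn(S(=O)(=O)c3ccc(C)cc3)c3ccccc23)cc1`, which in this assay gives -13.9%, a number beyond the scatter below it; furthest away is compound 1 `Cc1ccc(S(=O)(=O)n2cc(CN(Cc3cn(Cc4ccccc4)nn3)S(=O)(=O)c3ccccc3)c3ccccc32)cc1`, which in this assay gives -18%, also beyond the scatter below compound 3. None of the three compounds shows marked inhibition, and two of them lie in negative territory.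

Compound 4 `Cc1ccc(S(=O)(=O)N(Cc2cn(Cc3ccccc3)nn2)Cc2cn(S(=O)(=O)c3ccc(C)cc3)c3ccccc23)cc1` is not yet measured and differs from compound 3 in one place: hydrogen in place of methoxy on an aromatic carbon. Among the measured compounds shown here, no step between measured compounds of this kind is available, so the size of the change in this assay can only be guessed. Given that compound 3 gives 1%, a near-zero read-out, the step from compound 3 to compound 4 is expected to be small, a number 5 percentage points lower from compound 3 to compound 4 (within the scatter), and not beyond the scatter. Compound 4 is therefore estimated at -4% in this assay, within a range from -24% to 14%.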

Compound 4, a percentage reported as inhibition, at one concentration (the size of the read-out at that concentration, not a potency): 3.4%
For compound 4 the middle estimate is 7.4 percentage points below the measured one, and the stated range covers the measured number.
By their numbers in this assay, from the lowest: compounds 1 and 2 (each within the scatter of the next); then compounds 3 and 4 (each within the scatter of the next).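

In this assay, the change from 4-methoxybenzyl to benzyl reads as a number 2.4 percentage points higher from compound 3 to compound 4 (within the scatter), so at this position, para to a large group, the read-out does not separate methoxy from hydrogen. Two other single changes do leave the scatter: methyl in place of hydrogen on an aromatic carbon gives a number 21.4 percentage points higher from compound 1 to compound 4 (beyond the scatter), and 1-benzyl-1H-1,2,3-triazol-4-yl in place of 2,3-difluorophenyl on a saturated chain carbon bound to a sulfonamide nitrogen gives a number 17.3 percentage points higher from compound 2 to compound 4 (beyond the scatter). Even so, compound 4 gives only 3.4%, so all of these steps end close to zero inhibition.

From the compounds shown here alone, whether a hydroxyl, an amine or a carboxylic acid at this para position would move the number remains open. Nothing given here explains any of these steps.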